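The source may hold more compounds than are shown below. What is called first, only, known or untested is meant among the compounds shown, and "the series" means these compounds.

Among the measured compounds shown here, compound 2 `O=C(/C=C/c1ccc(Cl)cc1)C[C@@H]1O[C@H](CO)[C@@H](O)[C@H](O)[C@H]1O` stands lowest of the three measured members: in an assay for inhibition of glucose-6-phosphatase catalytic subunit 1 (Rattus norvegicus), tested at 100 uM (on this read-out higher numbers stand for more inhibition at the one concentration tested (going by the name of the read-out) and lower numbers for less inhibition), compound 2 gives -25.3%, and the two other compounds lie beyond the scatter above it. Compound 1 `CCOC(=O)C(C(=O)OCC)C(CC(=O)C[C@@H]1O[C@H](CO)[C@@H](O)[C@H](O)[C@H]1O)c1cccnc1` gives 37.6% in this assay. Compound 3 `CCOC(=O)C(C(=O)OCC)C(CC(=O)C[C@@H]1O[C@H](CO)[C@@H](O)[C@H](O)[C@H]1O)c1ccc(OC)c(OC)c1` gives 36.2% in this assay. For the measured compounds named here, the one single-place step measured so far, a number 1.4 percentage points lower from compound 1 to compound 3 (within the scatter), exchanges one aryl group for another on a saturated chain carbon and stays within the scatter.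

Compound 4 `O=C(/C=C/c1ccccc1)C[C@@H]1O[C@H](CO)[C@@H](O)[C@H](O)[C@H]1O` differs from compound 2 by hydrogen in place of chloro on an aromatic carbon. Going by the values given here, no measured step removes a substituent from the aromatic ring of this side chain, so the step from compound 2 to compound 4 has no direct precedent in the numbers. The measured step bears on it only loosely: it shows that exchanging one aryl group for another on the chain left this assay essentially unchanged, which gives no reason to expect a shift beyond the scatter here either. The expected step is therefore small, a number 7.3 percentage points higher from compound 2 to compound 4 (within the scatter), and within the scatter. Compound 4 is estimated at -18% in this assay, with a range from -40% to 5%.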

Compound 4, a percentage reported as inhibition, at one concentration (the size of the read-out at that concentration, not a potency): -49.7%
For compound 4 the middle estimate is 31.7 percentage points above the measured one; the measured number lies below the stated range.
By their numbers in this assay, from the lowest: compound 4; then compound 2; then compounds 3 and 1 (each within the scatter of the next).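

In this assay, among the compounds shown here, the 4-chlorophenyl to phenyl change is the first single-place step to go beyond the scatter, a number 24.4 percentage points lower from compound 2 to compound 4 (beyond the scatter). The read-out therefore responds to the group on this aromatic carbon, para to a large group, whereas the earlier step, a number 1.4 percentage points lower from compound 1 to compound 3 (within the scatter), exchanged one whole aryl group for another on a saturated chain carbon and left the number within the scatter. Both compounds of the new pair stay below zero, and nothing at hand bears on why removing the chloro moves the number in this direction.

On these data alone, whether this place answers to chloro alone or to other substituents stays open, and a fluoro, a methoxy or an amine on the same carbon of compound 4 would test that. Also open, as far as these compounds go, is how the side chain of compound 2 relates to the chain carrying two ethyl esters in compound 1 and compound 3, since these differ from compound 2 in more than one place and the gap cannot be assigned to any single group.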